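This account rests on a few compounds, and the source may have more. Where it says the series, first, only, none or still open, it means among the compounds named here.

In a functional assay (aorta) with Rattus norvegicus as the target (on this read-out higher numbers stand for an effect only at larger amounts of compound and lower numbers for an effect already at smaller amounts), three compounds have been measured:
compound 1 `CNC(=N)Nc1nc(-c2ccc(OC)cc2)c(-c2ccc(OC)cc2)s1`: 1.2 uM;
compound 2 `COc1ccc(-c2nc(/N=C(\N)NC(C)C)sc2-c2ccc(OC)cc2)cc1`: 9.1 uM;
compound 3 `COc1ccc(-c2nc(/N=C(\N)N(C)C)sc2-c2ccc(OC)cc2)cc1`: 4.8 uM.

Compound 2 has the highest of these three numbers; its gap to compound 3 is within the scatter, while the step of a 7.6-fold higher number from compound 1 to compound 2 (0.88 log units; beyond the scatter) lies beyond it. Compound 4 `COc1ccc(-c2nc(C(=O)N3CCOCC3)sc2-c2ccc(OC)cc2)cc1` differs from compound 2 by a group of 8 heavy atoms (5 carbon, 1 nitrogen, 2 oxygen; one six-membered non-aromatic ring with 2 hetero atoms) in place of a group of 7 heavy atoms (4 carbon, 3 nitrogen; no ring), on an aromatic carbon. The measured steps of a 4.0-fold higher number from compound 1 to compound 3 (0.60 log units; beyond the scatter) and a 1.9-fold lower number from compound 2 to compound 3 (0.28 log units; within the scatter), like the first, only vary the size of the group on that aromatic carbon; none shows what an exchange for a (morpholin-4-yl)carbonyl with its carbonyl and six-membered ring does. Every variation of that group so far has raised the number, so a bigger exchange is expected to raise it more. In this assay, for the measured compounds named here, compound 4 is expected to give 25 uM, between 6 uM and 100 uM, a step of a 2.7-fold higher number from compound 2 to compound 4 (0.44 log units; beyond the scatter), with wide uncertainty since no measured step covers such an exchange.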

Compound 4, concentration for half-maximal effect: < 100 uM
Compound 4: no number, only a limit (the forecaster's own chance of this, stated with the estimate: 25%); the middle value is on the limit's open side.
By their numbers in this assay, from the lowest: compound 1; then compounds 3 and 2 (each within the scatter of the next).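

In this assay compound 4 gives < 100 uM, a limit and not a number, so the steps from compound 1, compound 2 and compound 3 to compound 4 cannot be read. Going by these compounds, how far the exchange for (morpholin-4-yl)carbonyl moves the number, and in which direction, stays open.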